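Expecting a Methyl Step on the Core of Compound 3

The source may hold more compounds than are shown below. What is called first, only, known or untested is meant among the compounds shown, and "the series" means these compounds.

Four compounds share one core and differ in two places. Compound 1 `COc1cc2c(Nc3cccc(C#N)c3)ncnc2cc1OCCCN1CCCCC1` gives 37000 nM in a functional assay on A549 cells (Homo sapiens) for antiproliferative activity, read by MTT assay, with a stated time of 72 h; a lower number here means a stronger inhibitor, a higher number a weaker inhibitor. Compound 2 `COc1cc2c(Nc3cccc(C#N)c3)ncnc2cc1OCCCN1CCC(C)CC1` carries methyl in place of hydrogen on a saturated ring carbon; in this assay compound 2 gives 18700 nM, and the step is a 2.0-fold lower number from compound 1 to compound 2 (0.30 log units; within the scatter). Compound 3 `COc1cc2c(Nc3ccccc3C#N)ncnc2cc1OCCCN1CCCCC1` differs from compound 1 by 2-cyanophenyl in place of 3-cyanophenyl on a nitrogen on an aromatic ring; in this assay compound 3 gives 14700 nM, and the step is a 2.5-fold lower number from compound 1 to compound 3 (0.40 log units; beyond the scatter), the lowest number of the three measured.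

Compound 4 `COc1cc2c(Nc3ccccc3C#N)ncnc2cc1OCCCN1CCC(C)CC1` has not been measured. It differs from compound 3 by methyl in place of hydrogen on a saturated ring carbon, which is the same change as from compound 1 to compound 2, placed on the core of compound 3. Because the earlier instance of this change gave a 2.0-fold lower number from compound 1 to compound 2 (0.30 log units; within the scatter), a step of similar, modest size is expected here, namely a 1.6-fold lower number from compound 3 to compound 4 (0.21 log units; within the scatter), with the caution that one instance within the usual scatter is a thin basis. On that basis compound 4 is expected to give about 9000 nM in this assay, most likely between 4000 nM and 20000 nM.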

Compound 4, half-maximal inhibitory concentration: 22700 nM
Beside the measured number, compound 4's estimate is 2.5-fold (0.40 log units) below it, outside the stated range (above it).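

In this assay, methyl in place of hydrogen on the core of compound 3 gives a 1.5-fold higher number from compound 3 to compound 4 (0.19 log units; within the scatter), and this step does not match its earlier instance: the same change on two cores in this assay, a 2.0-fold lower number (0.30 log units; within the scatter) from compound 1 to compound 2 and a 1.5-fold higher number (0.19 log units; within the scatter) from compound 3 to compound 4, 3.1-fold (0.49 log units) apart, beyond the scatter of two such steps. Reading the other change on the methylated pair gives a 1.2-fold higher number from compound 2 to compound 4 (0.08 log units; within the scatter), and it also differs from its earlier instance: the same change on two cores in this assay, a 2.5-fold lower number (0.40 log units; beyond the scatter) from compound 1 to compound 3 and a 1.2-fold higher number (0.08 log units; within the scatter) from compound 2 to compound 4, 3.1-fold (0.49 log units) apart, beyond the scatter of two such steps. Both gaps come from the same four compounds and so form one finding, which shows that in this series the size of a step on one core cannot simply be carried to the other, but it does not show why, and neither new step alone separates compound 4 from its partner beyond the scatter.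

The compounds shown leave open whether an ethyl or a hydroxyl group in place of the methyl would give steps that agree across these two cores. They also leave open how the methyl step would behave on a third core.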